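A few compounds are considered here, and "the series" means these few. Any claim that something is new, unique, unknown or untested is made for them only; others in the source may bear on it.

Compound 1 `CCOC(=O)Nc1cc(NC(C)C(=O)COc2ccccc2)c([N+](=O)[O-])c(N)n1` gives 89000 nM
Compound 2 `CCOC(=O)Nc1cc(NC(C)C(=O)Cc2ccccc2)c([N+](=O)[O-])c(N)n1` gives 10000 nM

In a functional assay on L1210 cells (Mus musculus), with a stated time of 48 h (on this read-out lower numbers stand for stronger inhibition and higher numbers for weaker inhibition), compound 2 gives 10000 nM and stands lowest of the two measured. Compound 3 `CCCCC(=O)C(C)Nc1cc(NC(=O)OCC)nc(N)c1[N+](=O)[O-]` carries the change propyl in place of phenyl on a saturated chain carbon bound to a carbonyl carbon. Among the measured compounds shown here, only one measured step touches this place, an 8.9-fold lower number from compound 1 to compound 2 (0.95 log units; beyond the scatter) (phenyl in place of phenoxy), modest and beyond the scatter. On that evidence a step of like or smaller size is expected, toward a higher number. The expected step is a 2.5-fold higher number from compound 2 to compound 3 (0.40 log units; beyond the scatter) (an estimate). Compound 3 is estimated at 25000 nM (range 6000 nM to 90000 nM).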

Compound 3, half-maximal inhibitory concentration: 54000 nM
Compound 3: the middle estimate sits 2.2-fold (0.33 log units) below what was measured; the range from low to high includes it.
By their numbers in this assay, from the lowest: compound 2; then compounds 3 and 1 (each within the scatter of the next).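

In this assay, propyl in place of phenyl on a saturated chain carbon bound to a carbonyl carbon gives a 5.4-fold higher number from compound 2 to compound 3 (0.73 log units; beyond the scatter), so the open chain does not match the phenyl of compound 2. Propyl and phenoxy at this place read alike, with a 1.6-fold lower number from compound 1 to compound 3 (0.22 log units; within the scatter) lying within the scatter, and of the three only compound 2 stands apart. Nothing given here accounts for this difference.

As far as these compounds go, it remains open whether the aromatic ring itself counts, or only the size of the group. A cyclohexyl group, a longer chain such as hexyl, or an amine at this place could separate these readings.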